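Replacing a thiazolylamino group with a five-membered oxygen-rich ring

The source may hold more compounds than are shown below. What is called first, only, known or untested is meant among the compounds shown, and "the series" means these compounds.

Of the compounds shown here, three sharing one core have been measured in a physicochemical assay for solubility, measured as kinetic solubility, at pH 2; a higher number here means a more soluble compound, a lower number a less soluble compound. Compound 1 `CC(C)NC(=O)CC(c1ccc(-c2ccc3cccc(F)c3c2)[nH]c1=O)C(C)C` gives 24200 nM. Compound 2 `CC(C)C(Nc1nccs1)c1ccc(-c2ccc3cccc(F)c3c2)[nH]c1=O` gives 32900 nM, and compound 3 `CC(C)[C@H](C[C@H]1CCNC1=O)c1ccc(-c2ccc3cccc(F)c3c2)[nH]c1=O` gives 38300 nM. Compound 2 stands second highest of the three numbers, with compound 3 the nearest and compound 1 the furthest, but both gaps lie within the scatter, so the three are effectively indistinguishable. Going by the values given here, the only measured step, a 1.4-fold higher number from compound 1 to compound 2 (0.13 log units; within the scatter), is likewise within the scatter.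

Compound 4 `CC(C)C(c1noc(=O)[nH]1)c1ccc(-c2ccc3cccc(F)c3c2)[nH]c1=O` is not yet measured. Compared with compound 2 it carries a different group at the same place: a group of 6 heavy atoms (2 carbon, 2 nitrogen, 2 oxygen; one five-membered aromatic ring with 3 hetero atoms) in place of a group of 6 heavy atoms (3 carbon, 2 nitrogen, 1 sulfur; one five-membered aromatic ring with 2 hetero atoms), on a saturated chain carbon bound to an aromatic carbon and a saturated chain carbon. Among the compounds with values here, no measured step involves this new ring, so the expectation rests on how little the numbers have moved so far. Because a 1.4-fold higher number from compound 1 to compound 2 (0.13 log units; within the scatter) stayed within the scatter, the expected step is a 1.1-fold lower number from compound 2 to compound 4 (0.04 log units; within the scatter), with no clear direction. Compound 4 is therefore estimated at 30000 nM, with a range from 12000 nM to 75000 nM.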

Compound 4, solubility: 23200 nM
Beside the measured number, compound 4's estimate is 1.3-fold (0.11 log units) above it; the measured number falls inside the stated range.
By their numbers in this assay, from the lowest: compounds 4, 1, 2 and 3 (each within the scatter of the next).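

Putting a five-membered aromatic ring with 3 hetero atoms in place of the (1,3-thiazol-2-yl)amino group, on this saturated chain carbon, gives a 1.4-fold lower number from compound 2 to compound 4 (0.15 log units; within the scatter) in this assay. The same ring in place of the (isopropylcarbamoyl)methyl group gives a 1.0-fold lower number from compound 1 to compound 4 (0.02 log units; within the scatter), so the result extends what the earlier step showed: compounds 1, 2 and 4 carry three different groups at this place, two of them aromatic rings with different hetero atoms, and each pair remains within the scatter. No supporting measurement is available to explain these results.

On these data alone, whether an amine, a carboxylic acid or a longer chain at this place would give a step beyond the scatter remains open. With every step here so small, the compounds shown also leave open which features of the group at this place, if any, can shift the number.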